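The compounds below may be only part of what the source reports. "The series", "measured", "known", "first", "only" and "open" are said of these compounds alone.

Three compounds share one core and differ only in the group carried on the amide-type nitrogen. In an ADME assay on HepG2 2.2.15 cells (Homo sapiens) for cytotoxicity, read by MTT assay, with stated times of 48 h and 9 days (on this read-out higher numbers stand for lower toxicity in this test and lower numbers for higher toxicity in this test), compound 1 `COc1ccc2c(=O)c(/C=C/C(=O)NCc3ccc(C)cc3)coc2c1` gives 257000 nM, compound 2 `COc1ccc2c(=O)c(/C=C/C(=O)NCc3ccccc3F)coc2c1` gives 146000 nM, and compound 3 `COc1ccc2c(=O)c(/C=C/C(=O)Nc3ccccc3OC)coc2c1` gives 1050000 nM, the highest of the three. The steps of a 4.1-fold higher number from compound 1 to compound 3 (0.61 log units; beyond the scatter) and a 7.2-fold higher number from compound 2 to compound 3 (0.86 log units; beyond the scatter) both replaced a benzyl-type group by a methoxyphenyl on that nitrogen, whereas a 1.8-fold lower number from compound 1 to compound 2 (0.25 log units; within the scatter) changed only the ring on the saturated chain carbon. Compound 4 `COc1cccc(NC(=O)/C=C/c2coc3cc(OC)ccc3c2=O)c1` keeps the methoxyphenyl and changes only (3-methoxyphenyl in place of 2-methoxyphenyl on an amide-type nitrogen). Going by the values given here, no measured step shifts a methoxy group within its ring, so no direction is predicted and a step within the scatter is expected, a 1.3-fold lower number from compound 3 to compound 4 (0.12 log units; within the scatter). Compound 4 is therefore estimated at 800000 nM, between 300000 nM and 2000000 nM.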

Compound 4, half-maximal cytotoxic concentration: 1130000 nM
Estimate against measurement, compound 4: 1.4-fold (0.15 log units) below; measured number inside the range.
By their numbers in this assay, from the lowest: compounds 2 and 1 (each within the scatter of the next); then compounds 3 and 4 (each within the scatter of the next).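

In this assay moving the methoxy group from 2-methoxyphenyl to 3-methoxyphenyl on the amide-type nitrogen changes nothing beyond the scatter (a 1.1-fold higher number from compound 3 to compound 4 (0.03 log units; within the scatter)). The gap to the benzyl-type groups also holds for this second methoxyphenyl compound (a 7.7-fold higher number from compound 2 to compound 4 (0.89 log units; beyond the scatter); a 4.4-fold higher number from compound 1 to compound 4 (0.64 log units; beyond the scatter)), so it does not depend on one methoxy placement. No measurement shown gives a reason for this.

Still open, on these data alone, is whether the higher numbers go with the methoxy group or with the ring sitting directly on the nitrogen. A plain phenyl or a 3-methoxybenzyl group could separate the two.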